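Acetyl to 1-Hydroxyethyl on the Phenoxy Arm

The compounds below may be only part of what the source reports. "The series", "measured", "known", "first", "only" and "open" are said of these compounds alone.

Measured compounds in a functional assay on HeLa cells (Homo sapiens) for antiproliferative activity, read by cell counting, with a stated time of 3 days; a higher number here means a weaker inhibitor, a lower number a stronger inhibitor:
compound 1, `CC(=O)c1ccc(Oc2ccccc2NC(C)=C2C(=O)CC(c3ccccc3)CC2=O)cc1`: 130 nM
compound 2, `COc1ccc(Oc2ccccc2NC(C)=C2C(=O)CC(c3ccccc3)CC2=O)cc1`: 160 nM
compound 3, `COc1ccc(Oc2ccccc2NC(C)=C2C(=O)CC(c3ccccc3)CC2=O)cc1OC`: 54 nM

Compound 1 stands second highest of the three numbers; compound 2 lies within the scatter of it, a 1.2-fold higher number from compound 1 to compound 2 (0.09 log units; within the scatter), while compound 3 is a modest step away, a 2.4-fold lower number from compound 1 to compound 3 (0.38 log units; beyond the scatter). Compound 4, `CC(Nc1ccccc1Oc1ccc(C(C)O)cc1)=C1C(=O)CC(c2ccccc2)CC1=O`, differs from compound 1 as follows: 1-hydroxyethyl in place of acetyl on an aromatic carbon. For the measured compounds named here, the one measured step at this position, the change from acetyl to methoxy, a 1.2-fold higher number from compound 1 to compound 2 (0.09 log units; within the scatter), stayed within the scatter; the larger steps to compound 3 involve a different ring position and bear less directly. A small change in this assay, of either direction, is therefore expected for compound 4. Its value is estimated at 150 nM, in the range 60 nM to 400 nM, a step of a 1.2-fold higher number from compound 1 to compound 4 (0.06 log units; within the scatter).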

Compound 4, half-maximal inhibitory concentration: 75 nM
The estimate for compound 4 lay 2.0-fold (0.30 log units) above the measured number, and the stated range covers the measured number.
By their numbers in this assay, from the lowest: compounds 3, 4, 1 and 2 (each within the scatter of the next, the first and the last beyond it).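

In this assay, 1-hydroxyethyl, which carries a hydrogen-bond donor that acetyl lacks, stays within the scatter of acetyl (a 1.7-fold lower number from compound 1 to compound 4 (0.24 log units; within the scatter)) and of the 3,4-dimethoxyphenyl compound (a 1.4-fold higher number from compound 3 to compound 4 (0.14 log units; within the scatter)). Against methoxy at the same place it stands beyond the scatter (a 2.1-fold lower number from compound 2 to compound 4 (0.33 log units; beyond the scatter)), so this position can yield a modest step, although acetyl and methoxy could not be separated. Nothing measured here accounts for this difference. The compounds shown leave open how hydroxymethyl, an amine or a carboxylic acid at this position would read, and whether the two mirror-image forms of 1-hydroxyethyl would read alike.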